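Para-methoxy in place of tert-butyl on the benzyl group

The source may report more compounds than this note shows. Statements on the series, on what has been measured and on what is new or still open speak of the compounds shown alone.

Measured compounds:
compound 1 `CC(C)(C)c1ccc(CNCCCNS(=O)(=O)c2cc(C(F)(F)F)cc(C(F)(F)F)c2)cc1` gives 2100 nM
compound 2 `COc1cccc(CNCCCNS(=O)(=O)c2cc(C(F)(F)F)cc(C(F)(F)F)c2)c1` gives 2400 nM
compound 3 `O=S(=O)(NCCCNCc1ccccc1Cl)c1cc(C(F)(F)F)cc(C(F)(F)F)c1` gives 8800 nM

In a functional assay on MCF7 cells (Homo sapiens) for inhibition, read by MTT assay, with a stated time of 72 h (a higher number here means a weaker inhibitor of growth, a lower number a stronger inhibitor of growth), compound 1 holds the lowest number of the three, with compound 2 within the scatter of it and compound 3 the furthest away. Compound 4 `COc1ccc(CNCCCNS(=O)(=O)c2cc(C(F)(F)F)cc(C(F)(F)F)c2)cc1` differs from compound 1 by methoxy in place of tert-butyl on an aromatic carbon. Among the compounds with values here, no measured step makes this exact change. The nearest is a 1.1-fold higher number from compound 1 to compound 2 (0.06 log units; within the scatter), where a 3-methoxyphenyl group replaces the 4-(tert-butyl)phenyl group without a shift beyond the scatter, while a 4.2-fold higher number from compound 1 to compound 3 (0.62 log units; beyond the scatter) shows a modest loss for a 2-chlorophenyl group. A methoxy group on the ring is therefore expected to cost little, so compound 4 is estimated at 2800 nM (range 1400 nM to 6000 nM), an expected step of a 1.3-fold higher number from compound 1 to compound 4 (0.12 log units; within the scatter).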

Compound 4, concentration for 50% growth inhibition: 2500 nM
Compound 4: the middle estimate sits 1.1-fold (0.05 log units) above what was measured, within the range that was stated.
By their numbers in this assay, from the lowest: compounds 1, 2 and 4 (each within the scatter of the next); then compound 3.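

In this assay the direct exchange of tert-butyl for methoxy on this aromatic carbon gives a 1.2-fold higher number from compound 1 to compound 4 (0.08 log units; within the scatter) and so does not separate the 4-(tert-butyl)phenyl and 4-methoxyphenyl compounds. The 3-methoxyphenyl and 4-methoxyphenyl compounds also stand together, with a 1.0-fold higher number from compound 2 to compound 4 (0.02 log units; within the scatter) as their step, whereas the 2-chlorophenyl compound stays apart from the 4-methoxyphenyl compound, with a 3.5-fold lower number from compound 3 to compound 4 (0.55 log units; beyond the scatter) as the step. Nothing measured here offers a reason for these steps. From the compounds shown here alone, whether an amine or a carboxylic acid on this aromatic carbon would hold the number stays open, as does the outcome of a longer chain in the linker.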